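A few compounds are considered here, and "the series" means these few. Any claim that something is new, unique, unknown or untested is made for them only; others in the source may bear on it.

Of the compounds shown here, three have been tested in a functional assay on MCF7 cells (Homo sapiens) for cytotoxicity, read by MTT assay, with a stated time of 48 h; a lower number here means a stronger inhibitor, a higher number a weaker inhibitor. Compound 1 `CCCCCCCCCNC(=O)N(Cc1cc(OC)ccc1OC)n1cnnc1` gives only a limit in this assay, > 50000 nM. Compound 2 `O=C(NCc1ccccc1)N(Cc1ccccn1)n1cnnc1` likewise gives only a limit in this assay, > 50000 nM. Going by the values given here, compound 3 `N#Cc1ccc(CN(C(=O)Nc2cc(C(F)(F)F)cc(C(F)(F)F)c2)n2cnnc2)cc1` is the single member with a measured number: in this assay compound 3 gives 7220 nM. Where compound 2 stands is therefore plain: it sits at the limit of > 50000 nM in this assay, at which 2 of the 3 values shown sit, without a value of its own, and compound 1 shares that position. Compound 3 alone lies inside the measurable range.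

The step followed here leads from compound 2 to compound 4 `O=C(NC1CCCCC1)N(Cc1ccccn1)n1cnnc1`. The change is cyclohexyl in place of benzyl on an amide-type nitrogen. Among the compounds with values here, no pair of measured compounds differs in this single way, so the size of such a step has not been measured anywhere in the set. With compound 2 at a limit, the outcome is expected to be a step that the limit leaves unreadable from compound 2 to compound 4, none beyond the scatter, with compound 4 most likely returning a limit as well. Compound 4 is expected to give 60000 nM in this assay, with a range from 20000 nM to 200000 nM.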

Compound 4, half-maximal inhibitory concentration: 46900 nM
Compound 4: middle estimate off by 1.3-fold (0.11 log units), on the high side, within the range that was stated.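

Compound 4 brings a number to this position, which compound 2 could not give: in this assay compound 4 gives 46900 nM. The change of benzyl to cyclohexyl on the amide-type nitrogen, which replaces an aromatic ring of carbon with a non-aromatic one, gives an at least 1.0-fold lower number from compound 2 to compound 4 (0.02 log units; that floor lies within the scatter), so it is not shown to move the reading beyond the scatter. The full size of the step stays unread because compound 2 has only a limit and no number of its own: the limit of > 50000 nM in this assay, at which 2 of the 4 values shown sit.

Going by these compounds, whether another kind of group on this amide-type nitrogen, such as a longer chain, an amine or a carboxylic acid, would bring the reading clearly away from that limit remains open. Also open, on these data alone, is whether a smaller ring of carbon, such as cyclopentyl, would differ from cyclohexyl by more than the scatter, or whether any ring at this place matters to the reading at all.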